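The compounds below may be only part of what the source reports. "The series", "measured", "known", "first", "only" and "open" are said of these compounds alone.

Working notes on the series. Compound 3 `Cc1nc(-c2ccc(C(F)(F)F)cc2)sc1CNc1ccc(C(=O)O)cc1` gives the lowest maximal response of the three measured in a functional assay on CHO cells for agonist activity at Free fatty acid receptor 1 (Homo sapiens), read by a luciferase reporter; on this read-out lower numbers stand for smaller maximal responses and higher numbers for larger maximal responses: compound 3 gives 10%. Compound 1 `Cc1nc(-c2ccc(C(F)(F)F)cc2)sc1CNc1ccc(CCC(=O)O)cc1` gives 108%, and compound 2 `O=C(O)c1ccc(NCc2cccc(Oc3ccccc3)c2)cc1`, built on another core, gives 86%. Going by the values given here, the one measured step that bears on the next change is a number 98 percentage points lower from compound 1 to compound 3 (beyond the scatter), the exchange of 2-carboxyethyl for carboxy on an aromatic carbon. Compound 4 `Cc1nc(-c2ccc(C(F)(F)F)cc2)sc1CNc1ccc(CC(=O)O)cc1` takes the middle path: carboxymethyl in place of carboxy on an aromatic carbon. Among the compounds with values here, no measured step covers carboxymethyl itself, so the chain length between the two measured ends is untested; the expectation is that the response recovers part of the way, a step of a number 45 percentage points higher from compound 3 to compound 4 (beyond the scatter) in this assay. Compound 4 is therefore estimated at 55%, within 15% to 105%.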

Compound 4, largest response reached (reported as percent of maximum), in percent of the reference or control that the assay uses: 18%
The estimate for compound 4 lay 37 percentage points above the measured number; measured number inside the range.
By their numbers in this assay, from the lowest: compounds 3 and 4 (each within the scatter of the next); then compound 2; then compound 1.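

In this assay, carboxymethyl in place of carboxy on the aromatic carbon gives no change beyond the scatter (a number 8 percentage points higher from compound 3 to compound 4 (within the scatter)). The large change on this chain lies instead between carboxymethyl and 2-carboxyethyl (a number 90 percentage points lower from compound 1 to compound 4 (beyond the scatter)), so adding length here does not raise the response in even steps across the three compounds sharing this core. Nothing at hand accounts for this sharp dependence on chain length. Still open, on these data alone, is whether a longer chain than 2-carboxyethyl keeps the response on the core of compound 1. Also open, as far as these compounds go, is whether a tetrazole or an amide can stand in for the carboxylic acid.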